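Dimethylamino in place of methoxy: solubility expectation

The source may hold more compounds than are shown below. What is called first, only, known or untested is meant among the compounds shown, and "the series" means these compounds.

Compound 1 `COc1cccc(Oc2ccc3c(NCCCNCc4cc(F)ccc4OC)ccnc3c2)c1` gives 14500 nM in a physicochemical assay for solubility, with a stated time of 18 h, at pH 7.4; a higher number here means a more soluble compound, a lower number a less soluble compound. Compound 2 `COc1cccc(Oc2ccc3c(NCCCNCc4ccco4)ccnc3c2)c1` gives 14500 nM and compound 3 `COc1cccc(Oc2ccc3c(NCCCNCc4cccc(OC)c4O)ccnc3c2)c1` gives 14500 nM, so compound 1 stands level with both. The three measured steps, no change at the digits printed from compound 1 to compound 2 (within the scatter), no change at the digits printed from compound 1 to compound 3 (within the scatter) and no change at the digits printed from compound 2 to compound 3 (within the scatter), all vary the group on the saturated chain carbon bound to the amine nitrogen. Compound 4 `COc1ccc(F)cc1CNCCCNc1ccnc2cc(Oc3cccc(N(C)C)c3)ccc12` differs from compound 1 at another place: dimethylamino in place of methoxy on an aromatic carbon. For the measured compounds named here, no measured step touches this position, so the measured steps bear on it only indirectly, by showing that every change tried so far has left this assay flat. A step of no change at the digits printed from compound 1 to compound 4 (within the scatter) is therefore expected, none beyond the scatter. Compound 4 is estimated at 14500 nM, within 6000 nM to 35000 nM.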

Compound 4, solubility: 14500 nM
Estimate against measurement, compound 4: no gap at the digits printed; low and high end bracket the measured number.
By their numbers in this assay, from the lowest: compounds 1, 2, 3 and 4 (each within the scatter of the next).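

Dimethylamino in place of methoxy on an aromatic carbon, a position none of the earlier steps touched, gives no change at the digits printed from compound 1 to compound 4 (within the scatter) in this assay. The flat reading therefore extends beyond the group on the saturated chain carbon to this aromatic position, though only for this one replacement. Nothing available explains why the number holds.

Still open, from the compounds shown here alone, is whether a carboxylic acid in place of methoxy on this aromatic carbon would leave this assay equally flat. Equally open, going by these compounds, is whether a longer chain in the shared core would move the number at all.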